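Fluoro for methyl on a second core

The source may hold more compounds than are shown below. What is called first, only, known or untested is meant among the compounds shown, and "the series" means these compounds.

In a functional assay on HT-29 cells (Homo sapiens) for cytotoxicity, read by MTT assay, with a stated time of 72 h (a higher number here means a weaker inhibitor, a lower number a stronger inhibitor), compound 2 `COc1cc2c(Oc3ccc(NC(=O)c4cc(-c5ccc(C)cc5)ccn4)cc3F)ccnc2cc1OCCCN1CCCCC1` gives 340 nM. Its partner compound 1 `COc1cc2c(Oc3ccc(NC(=O)c4cc(-c5ccc(F)cc5)ccn4)cc3F)ccnc2cc1OCCCN1CCCCC1` gives 1370 nM in this assay. The change between them is fluoro in place of methyl on an aromatic carbon, and it made a 4.0-fold higher number from compound 2 to compound 1 (0.61 log units; beyond the scatter). Compound 3 `COc1cc2c(Oc3ccc(NC(=O)c4nccc(-c5ccc(C)cc5)n4)cc3F)ccnc2cc1OCCCN1CCN(C)CC1` gives 210 nM in this assay; the difference between its core and that of compound 2 is not broken down here. Compound 4 `COc1cc2c(Oc3ccc(NC(=O)c4nccc(-c5ccc(F)cc5)n4)cc3F)ccnc2cc1OCCCN1CCN(C)CC1` has not yet been measured in this assay. It differs from compound 3 by fluoro in place of methyl on an aromatic carbon, the same change as that from compound 2 to compound 1, at the same kind of place. Since that earlier change gave a 4.0-fold higher number from compound 2 to compound 1 (0.61 log units; beyond the scatter), a step of about a 3.8-fold higher number from compound 3 to compound 4 (0.58 log units; beyond the scatter) is expected here. The value of compound 4 in this assay is estimated at 800 nM, between 350 nM and 1800 nM.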

Compound 4, half-maximal inhibitory concentration: 42 nM
Beside the measured number, compound 4's estimate is 19-fold (1.28 log units) above it, and the stated range ends above it.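

On the second core, fluoro in place of methyl gave a 5.0-fold lower number from compound 3 to compound 4 (0.70 log units; beyond the scatter) in this assay, a step in the opposite direction to the one on the first core. Set side by side, the two steps disagree, so in this series the change cannot be carried from one core to the other as a fixed step: the same change on two cores in this assay, a 4.0-fold higher number (0.61 log units; beyond the scatter) from compound 2 to compound 1 and a 5.0-fold lower number (0.70 log units; beyond the scatter) from compound 3 to compound 4, 20-fold (1.30 log units) apart, beyond the scatter of two such steps The two cores differ in more than one place, and these two pairs do not show which difference goes with the reversal, nor how the change would behave on any further core.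

On these data alone, it remains open whether chloro or methoxy in place of the fluoro would also separate the two cores. A single pair on each core cannot settle whether the reversal extends beyond 4-fluorophenyl.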